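A few compounds are considered here, and "the series" means these few. Any claim that something is new, unique, unknown or untested is made for them only; others in the source may bear on it.

Measured compounds:
compound 1 `Cc1ccc(N2CCN(C(=O)c3oc(C)nc3-c3ccccc3)CC2)cc1` in a functional assay on HL-60 cells (Homo sapiens) for inhibition, read by MTT assay, with a stated time of 72 h; on this read-out lower numbers stand for stronger inhibition and higher numbers for weaker inhibition: > 1000 nM, a limit of the assay rather than a number.
compound 2 `Cc1nc(-c2ccccc2)c(C(=O)N2CCN(c3ccccc3)CC2)o1` in this assay: 39.1 nM
compound 3 `COc1cc(OC)cc(N2CCN(C(=O)c3oc(C)nc3-c3ccccc3)CC2)c1` in this assay: 19.2 nM

Compound 3 stands lowest of the two numbers shown, with compound 2 nearest: a 2.0-fold lower number from compound 2 to compound 3 (0.31 log units; beyond the scatter). The remaining value is a limit, (the limit of > 1000 nM in this assay, at which 1 of the 3 values shown sits).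

Compound 4 `COc1cccc(N2CCN(C(=O)c3oc(C)nc3-c3ccccc3)CC2)c1` has not yet been measured. It differs from compound 3 by hydrogen in place of methoxy on an aromatic carbon, so the aryl group on the ring nitrogen goes from 3,5-dimethoxyphenyl to 3-methoxyphenyl. Going by the values given here, no measured step removes a single methoxy group, but two steps concern the same aryl group: a 2.0-fold lower number from compound 2 to compound 3 (0.31 log units; beyond the scatter), in which both methoxy groups enter together, and an at least 52-fold lower number from compound 1 to compound 3 (1.71 log units; beyond the scatter), which starts from a limit and so gives only a floor for its size. Compound 4 keeps one of the two methoxy groups, so a number between those of compound 2 and compound 3 is expected, a modest rise from compound 3 that may well stay within the scatter. Compound 4 is estimated at 28 nM, with a range from 12 nM to 70 nM, meaning a step of a 1.5-fold higher number from compound 3 to compound 4 (0.16 log units; within the scatter).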

Compound 4, half-maximal inhibitory concentration: 34.8 nM
Compound 4: the middle estimate sits 1.2-fold (0.09 log units) below what was measured; the measured number falls inside the stated range.
By their numbers in this assay, from the lowest: compounds 3, 4 and 2 (each within the scatter of the next, the first and the last beyond it). At a limit, above all of these: compound 1.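

In this assay, one methoxy group can now be read apart from two: a 1.1-fold lower number from compound 2 to compound 4 (0.05 log units; within the scatter), and a 1.8-fold higher number from compound 3 to compound 4 (0.26 log units; within the scatter). Each single-methoxy step lies within the scatter, so the modest gap printed for the pair with both methoxy groups, this assay, cannot be assigned to either group alone. The large step of an at least 28-fold lower number from compound 1 to compound 4 (1.45 log units; beyond the scatter) gives only a floor for its size, because one end of it is a limit of the assay: the limit of > 1000 nM in this assay, at which 1 of the 4 values shown sits.

Still open, going by these compounds, is whether a 3-hydroxyphenyl or 3-chlorophenyl group would stay in the same range as 3-methoxyphenyl. Also open, on these data alone, is whether the limit seen with 4-methylphenyl belongs to the methyl group or to its place on the ring, which 3-methylphenyl and 4-methoxyphenyl groups on the same core would separate.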